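The source may hold more compounds than are shown below. What is called first, only, known or untested is meant among the compounds shown, and "the series" means these compounds.

Of the compounds shown here, three have been measured in an assay for binding affinity to dual specificity mitogen-activated protein kinase kinase 4 (Homo sapiens), read by KINOMEscan, tested at 10 nM; a higher number here means a weaker effect of the compound at the concentration tested, a lower number a stronger effect: compound 1 `CCCS(=O)(=O)Nc1ccc(F)c(C(=O)c2n[nH]c3ncc(-c4ccc(N)cc4)cc23)c1F` with 3.7%, compound 2 `CCCS(=O)(=O)Nc1ccc(F)c(C(=O)c2n[nH]c3ncc(-c4ccc(S(=O)(=O)NCC)cc4)cc23)c1F` with 41%, and compound 3 `CCCS(=O)(=O)Nc1ccc(F)c(C(=O)c2n[nH]c3ncc(-c4ccc(-c5nnn[nH]5)cc4)cc23)c1F` with 1.1%.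

Compound 3 stands lowest of the three in this assay; compound 1 lies within the scatter of it, while compound 2 sits clearly apart. Compound 4 `CCCS(=O)(=O)Nc1ccc(F)c(C(=O)c2n[nH]c3ncc(-c4ccc(S(N)(=O)=O)cc4F)cc23)c1F` differs from compound 3 by 2-fluoro-4-sulfamoylphenyl in place of 4-(1H-tetrazol-5-yl)phenyl on an aromatic carbon. The step that bears most on this change is a number 39.9 percentage points lower from compound 2 to compound 3 (beyond the scatter), which is now partly reversed, a sulfamoyl group entering where the 1H-tetrazol-5-yl stood; the step of a number 37.3 percentage points higher from compound 1 to compound 2 (beyond the scatter) points the same way. A rise beyond the scatter is therefore expected for compound 4 in this assay, a number 18.9 percentage points higher from compound 3 to compound 4 (beyond the scatter), with an estimated 20% in the range 3% to 60%.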

Compound 4, a percentage reported as activity, at one concentration (the size of the read-out at that concentration, not a potency): 9.4%
Estimate against measurement, compound 4: 10.6 percentage points above; low and high end bracket the measured number.
By their numbers in this assay, from the lowest: compounds 3, 1 and 4 (each within the scatter of the next); then compound 2.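

In this assay, the sulfamoyl group is compatible with a low number at this position, as the step to 2-fluoro-4-sulfamoylphenyl shows: a number 8.3 percentage points higher from compound 3 to compound 4 (within the scatter) and a number 5.7 percentage points higher from compound 1 to compound 4 (within the scatter). The large shift from the ethylsulfamoyl compound, a number 31.6 percentage points lower from compound 2 to compound 4 (beyond the scatter), shows that the high number of compound 2 does not extend to every sulfamoyl-bearing phenyl group. No evidence here accounts for this result.

On these data alone, compound 4 differs from compound 2 in both the fluorine and the ethyl group, so their separate shares remain open. As far as these compounds go, how an unfluorinated 4-sulfamoylphenyl group or a carboxylic acid in place of the sulfamoyl would read also remains open.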